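This account rests on a few compounds, and the source may have more. Where it says the series, first, only, none or still open, it means among the compounds named here.

This account follows a single change to the amine-bound side chain of a series of anilide compounds, tested in a functional assay on the whole organism for antagonist activity, with Mus musculus as the target; on this read-out higher numbers stand for an effect only at larger amounts of compound and lower numbers for an effect already at smaller amounts. The parent is compound 1 `COc1cc(N)c(Cl)cc1NC(=O)C1CCN(C/C=C/c2ccccc2)CC1`. In this assay compound 1 gives only a limit, > 10 mg/kg, so its place among the measured compounds is fixed by the limit of > 10 mg/kg in this assay, at which 1 of the 3 values shown sits, rather than by a number.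

Two measured neighbours frame the change. Compound 2 `COc1ccc(CN2CCC(C(=O)Nc3cc(Cl)c(N)cc3OC)CC2)cc1` gives 0.9 mg/kg in this assay, and the step of an at least 11-fold lower number from compound 1 to compound 2 (1.04 log units; beyond the scatter) is the clearest lead here. Compound 3 `COc1cc(N)c(Cl)cc1NC(=O)C1CCN(Cc2ccc(O)cc2)CC1` gives only a limit, > 8 mg/kg. The step that the two limits leave unreadable from compound 1 to compound 3 cannot be sized, while an at least 8.8-fold higher number from compound 2 to compound 3 (0.94 log units; beyond the scatter) shows how strongly the replacement of methyl by hydrogen on the ring oxygen weakens the effect.

Compound 4 `COc1cc(N)c(Cl)cc1NC(=O)C1CCN(Cc2ccsc2)CC1` carries the difference (thiophen-3-yl in place of 2-phenylethenyl on a saturated chain carbon bound to an amine nitrogen in a ring). Like compound 2, it puts a small aromatic ring directly on the chain carbon, so a lower number than compound 1 is expected, though without the methoxy group a smaller gain than an at least 11-fold lower number from compound 1 to compound 2 (1.04 log units; beyond the scatter) is estimated, about an at least 3.3-fold lower number from compound 1 to compound 4 (0.52 log units; beyond the scatter). The expected value for compound 4 is 3 mg/kg, within 1 mg/kg to 10 mg/kg.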

Compound 4, dose for half-maximal effect: 3.4 mg/kg
Compound 4: middle estimate off by 1.1-fold (0.05 log units), on the low side, within the range that was stated.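

Swapping 2-phenylethenyl for thiophen-3-yl, on a saturated chain carbon bound to an amine nitrogen in a ring, gives an at least 2.9-fold lower number from compound 1 to compound 4 (0.46 log units; beyond the scatter), so 4-methoxyphenyl is not the only group here that brings a readable dose in this assay. Thiophen-3-yl also outdoes 4-hydroxyphenyl, with an at least 2.3-fold lower number from compound 3 to compound 4 (0.37 log units; beyond the scatter), yet it falls short of 4-methoxyphenyl, with a 3.8-fold higher number from compound 2 to compound 4 (0.58 log units; beyond the scatter), which places compound 4 in the middle of this small set. The first of these steps is only a minimum size, because compound 1 gives just a limit: the limit of > 10 mg/kg in this assay, at which 1 of the 4 values shown sits.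

On these data alone, the true size of the step from compound 3 also stays open, because compound 3 gives just a limit too: the limit of > 8 mg/kg in this assay, at which 1 of the 4 values shown sits. Also open is where a plain phenyl ring, with neither methoxy nor hydroxy, would fall on the same chain carbon.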